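Pyridinyl to Methylthiazolyl on the Dienone Arm of Compound 3

The source may report more compounds than this note shows. Statements on the series, on what has been measured and on what is new or still open speak of the compounds shown alone.

Three compounds in the series have a number in a functional assay on MGC-803 cells (Homo sapiens) for antiproliferative activity, read by MTT assay, with a stated time of 48 h; on this read-out lower numbers stand for stronger inhibition and higher numbers for weaker inhibition. Compound 1 `O=C(/C=C/c1ccc(Oc2cc(=O)oc3ccccc23)cc1)/C=C/c1ccccn1` gives 19400 nM. For the measured compounds named here, compound 2 `COc1ccc(/C=C/C(=O)/C=C/c2ccc(Oc3cc(=O)oc4ccccc34)cc2)cc1OC` gives 49400 nM, and the step of a 2.5-fold higher number from compound 1 to compound 2 (0.41 log units; beyond the scatter) is the only change at this position that has been measured so far. Compound 3 `COc1cc(OC)c2c(=O)c(OCCCOc3ccccc3/C=C/C(=O)/C=C/c3ccccn3)c(-c3cc(OC)c(OC)c(OC)c3)oc2c1`, built on a different core, gives 560 nM and stands lowest of the three numbers shown, with compound 1 nearest and compound 2 furthest from it.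

Compound 4 `COc1cc(OC)c2c(=O)c(OCCCOc3ccccc3/C=C/C(=O)/C=C/c3scnc3C)c(-c3cc(OC)c(OC)c(OC)c3)oc2c1` keeps the core of compound 3 and differs from it in one place: 4-methyl-1,3-thiazol-5-yl in place of pyridin-2-yl on a double-bonded chain carbon bound to a double-bonded chain carbon. Going by the values given here, no measured step swaps a pyridinyl for a thiazolyl; the step from compound 1 to compound 2 is the only one that bears on the same position, and it was modest. Both groups leaving and entering here are small aromatic heterocycles of the same heavy-atom count, so the expected shift is estimated to be small and, if anything, toward a somewhat higher number, in line with what compound 1 and compound 2 show. For compound 4 the expected step is a 1.4-fold higher number from compound 3 to compound 4 (0.15 log units; within the scatter), and its value in this assay is estimated at 800 nM, within a range from 300 nM to 2500 nM.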

Compound 4, half-maximal inhibitory concentration: 5570 nM
Compound 4: middle estimate off by 7.0-fold (0.84 log units), on the low side, and the stated range ends below it.
By their numbers in this assay, from the lowest: compound 3; then compound 4; then compound 1; then compound 2.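

On the core of compound 3, in this assay, 4-methyl-1,3-thiazol-5-yl in place of pyridin-2-yl gives a 9.9-fold higher number from compound 3 to compound 4 (1.00 log units; beyond the scatter), so this position on the dienone arm responds to a swap between two aromatic heterocycles of the same heavy-atom count. For the compounds shown here, the only earlier change at this place, on a different core, was a 2.5-fold higher number from compound 1 to compound 2 (0.41 log units; beyond the scatter), and the new step is the larger of the two, which shows that replacing pyridin-2-yl raises the number in both cases, whether a 3,4-dimethoxyphenyl or a 4-methyl-1,3-thiazol-5-yl enters. Nothing in the available data explains why the number rises at this position.

The compounds shown leave open whether the step follows the methyl group or the change from a six-membered to a five-membered aromatic ring, a question that an unsubstituted 1,3-thiazol-5-yl on the core of compound 3 would help to separate. They also leave open whether the same swap gives a step of similar size on the core of compound 1, and how a pyridin-3-yl or a plain phenyl would compare at this place.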